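Dichloro change on the phenol of compound 1

This account rests on a few compounds, and the source may have more. Where it says the series, first, only, none or still open, it means among the compounds named here.

In a functional assay on HeLa cells (Homo sapiens) for cytotoxicity, read by sulforhodamine B assay, with a stated time of 3 days (a higher number here means a weaker inhibitor, a lower number a stronger inhibitor), compound 1 `COc1ccc(CNc2c(-c3ccccc3O)nc3ccccn23)cc1` gives 15 nM, the lower of the two true numbers in the series. Compound 3 `COc1ccc(CNc2c(-c3cc([N+](=O)[O-])ccc3O)nc3ccccn23)cc1` gives 210 nM. Compound 2 `COc1ccc(Nc2c(-c3ccccc3O)nc3ccccn23)cc1` sits at a limit of the assay, > 10000 nM.

Compound 4 `COc1ccc(CNc2c(-c3cc(Cl)cc(Cl)c3O)nc3ccccn23)cc1` differs from compound 1 as follows: 3,5-dichloro-2-hydroxyphenyl in place of 2-hydroxyphenyl on an aromatic carbon. It carries 3,5-dichloro-2-hydroxyphenyl in place of 2-hydroxyphenyl on an aromatic carbon. Going by the values given here, only one measured step changes this phenyl group, a 14-fold higher number from compound 1 to compound 3 (1.15 log units; beyond the scatter), with nitro in place of hydrogen on an aromatic carbon. That single large rise points to a rise in this assay here too, expected to be smaller, though with a different group the evidence is thin. The expected size is a 4.7-fold higher number from compound 1 to compound 4 (0.67 log units; beyond the scatter). Compound 4 is estimated at 70 nM, with a range of 15 nM to 400 nM.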

Compound 4, half-maximal inhibitory concentration: 4160 nM
Beside the measured number, compound 4's estimate is 59-fold (1.77 log units) below it; measured number above the stated range.
By their numbers in this assay, from the lowest: compound 1; then compound 3; then compound 4. At a limit, above all of these: compound 2.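

In this assay, going by these compounds alone, the change to 3,5-dichloro-2-hydroxyphenyl gives a 280-fold higher number from compound 1 to compound 4 (2.44 log units; beyond the scatter), so added groups on this phenol ring can cost far more than the one earlier step, a 14-fold higher number from compound 1 to compound 3 (1.15 log units; beyond the scatter), suggested. Both substituted phenols shown, compound 3 and compound 4, lie above compound 1, and no compound shown goes against this. Nothing measured here gives a cause for this rise.

As far as these compounds go, it stays open whether a single chlorine carries the rise. From the compounds shown here alone, it also stays open whether a fluorine, a methoxy group or an amine on this ring would stay near compound 1 at 15 nM.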